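Replacing an Azetidinyl Pyridine on the Thiazole Core

The source may hold more compounds than are shown below. What is called first, only, known or untested is meant among the compounds shown, and "the series" means these compounds.

Three compounds share a core carrying a carboxymethyl group, a diaryl methyl group and a third aromatic ring. Compound 1 `O=C(O)Cc1sc(C(c2ccc(F)cc2)c2ccc(F)cc2)nc1-c1ccnc(N2CCC2)c1` carries 2-(azetidin-1-yl)pyridin-4-yl at that third position. In an in vitro functional assay on HEK285-7 cells for antagonist activity at prostaglandin D2 receptor 2 (Homo sapiens), read by BRET and beta-arrestin recruitment (on this read-out lower numbers stand for stronger inhibition and higher numbers for weaker inhibition), compound 1 gives only a limit, > 100000 nM, which means the assay reports no number for it. Compound 2 `O=C(O)Cc1sc(C(c2ccccc2)c2ccc(Cl)cc2)nc1-c1ccc(Cl)cc1` gives 75 nM in this assay. Compound 3 `O=C(O)Cc1sc(C(c2ccccc2)c2ccc(O)cc2)nc1-c1ccc(F)cc1` gives 30 nM in this assay. Among the three values shown, compound 1 stands at the limit (the limit of > 100000 nM in this assay, at which 1 of the 3 values shown sits), while compound 2 and compound 3 give measured numbers.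

Compound 4 `Nc1cc(-c2nc(C(c3ccc(F)cc3)c3ccc(F)cc3)sc2CC(=O)O)cc(F)n1` is not yet measured. It differs from compound 1 in one place: 2-amino-6-fluoropyridin-4-yl in place of 2-(azetidin-1-yl)pyridin-4-yl on an aromatic carbon.

Among the measured compounds shown here, no measured step between these compounds exists, so the size of the step from compound 1 to compound 4 in this assay is open; a move towards stronger inhibition is expected, but its size is uncertain. Compound 4 is estimated at 2000 nM in this assay, within 200 nM to 20000 nM, meaning an expected step of an at least 50-fold lower number from compound 1 to compound 4 (1.69 log units; beyond the scatter).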

Compound 4, half-maximal inhibitory concentration: 1400 nM
For compound 4 the middle estimate is 1.4-fold (0.15 log units) above the measured one; measured number inside the range.
By their numbers in this assay, from the lowest: compound 3; then compound 2; then compound 4. At a limit, above all of these: compound 1.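

The change to 2-amino-6-fluoropyridin-4-yl in place of 2-(azetidin-1-yl)pyridin-4-yl gives an at least 71-fold lower number from compound 1 to compound 4 (1.85 log units; beyond the scatter) in this assay. Among the compounds shown here, this is the first step here between two compounds that differ in one place, and it shows that, with the rest of compound 1 held the same, the group on this aromatic carbon can by itself move the result from a limit to a measured number. The true size of the step stays unknown, as one end of it is a limit: the limit of > 100000 nM in this assay, at which 1 of the 4 values shown sits.

The change swaps the azetidine ring for an amino group and adds a fluorine at once, so the compounds shown cannot separate these parts. A 2-aminopyridin-4-yl or a 2-fluoropyridin-4-yl group at this position would tell them apart.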